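The source may report more compounds than this note shows. Statements on the series, on what has been measured and on what is new or still open speak of the compounds shown alone.

Three related compounds have been tested in a functional assay on RBL-2H3 cells (Rattus norvegicus) for inhibition (on this read-out higher numbers stand for weaker inhibition and lower numbers for stronger inhibition), so far. Compound 1, with the structure `Cc1cc(C)nc(N/C(S)=N/[C@@H](C)c2cccc3ccccc23)c1`, gives only a limit in this assay, > 100000 nM. Compound 2, with the structure `C[C@@H](/N=C(\S)Nc1ccccn1)c1cccc2ccccc12`, likewise gives only a limit, > 100000 nM. Among the compounds with values here, compound 3, with the structure `Cc1csc(N/C(S)=N/[C@H](C)c2cccc3ccccc23)n1`, is the single compound with an actual number: in this assay compound 3 gives 25900 nM, so it stands as the only measured value among the three. Compounds 1 and 2 instead sit at the limit of > 100000 nM in this assay, at which 2 of the 3 values shown sit.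

Within the data shown here, the one measured step, an at least 3.8-fold lower number from compound 2 to compound 3 (0.58 log units; beyond the scatter), shows that exchanging the ring on the amine nitrogen can move the read-out by a worthwhile amount.

Compound 4, with the structure `Cc1cc(C)nc(N/C(S)=N/[C@H](C)c2cccc3ccccc23)c1`, is not yet measured. It differs from compound 3 in that ring: 4,6-dimethylpyridin-2-yl in place of 4-methyl-1,3-thiazol-2-yl on an amine nitrogen. This change runs opposite in kind to the measured step from compound 2 to compound 3, which replaced a pyridine-type ring with the thiazole ring; here the thiazole ring leaves and a pyridine-type ring returns, now carrying two methyl groups.

From that comparison, compound 4 is expected to give a weaker inhibition than compound 3, with an estimated step of a 3.1-fold higher number from compound 3 to compound 4 (0.49 log units; beyond the scatter). The estimated value for compound 4 in this assay is 80000 nM, likely falling between 25000 nM and 300000 nM, and it may well end up reported only as a limit.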

Compound 4, half-maximal inhibitory concentration: > 100000 nM
Compound 4: a limit, no number; the forecaster's own chance of this, stated with the estimate: 55%; middle value at least 1.2-fold (0.09 log units) away from the limit.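

In this assay, the ring on the amine nitrogen proves decisive for compound 3: replacing 4-methyl-1,3-thiazol-2-yl with 4,6-dimethylpyridin-2-yl gives an at least 3.8-fold higher number from compound 3 to compound 4 (0.58 log units; beyond the scatter), and the full size of this loss stays hidden behind a limit. Adding two methyl groups to the pyridine-type ring therefore does not produce a readable value, and neither does either drawn configuration of the dimethylpyridine compounds; the steps from compound 2 and compound 1 to compound 4 cannot be read, as each joins two limits, and so far only the thiazole compound gives an actual number: the limit of > 100000 nM in this assay, at which 3 of the 4 values shown sit. Compound 4 also completes a pair that isolates the stereocentre, although here the comparison yields no size: the fact that compounds 1 and 4 differ only in the configuration as drawn.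

Going by these compounds, it remains open whether the methyl group on the thiazole ring matters, and whether an unsubstituted 1,3-thiazol-2-yl or a phenyl ring on the amine nitrogen would give a lower number than compound 3. On these data alone, it is also open whether the stereocentre changes the read-out in a compound that stays within the measurable range.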